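Replacing the 4-cyclopropylpiperazin-1-yl group of compound 1

A few compounds are considered here, and "the series" means these few. Any claim that something is new, unique, unknown or untested is made for them only; others in the source may bear on it.

compound 1 `CN(C[C@H]1Cc2c(cccc2N2CCN(C3CC3)CC2)CN1)[C@H]1CCCc2cccnc21` gives 15.5% in an ADME assay on microsomes from liver (Homo sapiens) for metabolic stability, read by LC-MS, with a stated time of 10 min; a higher number here means that more of the compound is left, a lower number that less of the compound is left
compound 2 `CN(C[C@H]1Cc2c(cccc2N2CCN(Cc3ccccn3)CC2)CN1)[C@H]1CCCc2cccnc21` gives 4.2% in this assay

Of these two numbers, compound 1 stands higher, with 15.5% as the top of a very small set. Compound 3 `CN(C[C@H]1Cc2c(cccc2N2CCN3CCC[C@@H]3C2)CN1)[C@H]1CCCc2cccnc21` keeps the core of compound 1 and alters one group on an aromatic carbon: a group of 9 heavy atoms (7 carbon, 2 nitrogen; one five-membered non-aromatic ring with 1 hetero atom, one six-membered non-aromatic ring with 2 hetero atoms) in place of a group of 9 heavy atoms (7 carbon, 2 nitrogen; one three-membered non-aromatic ring of carbon only, one six-membered non-aromatic ring with 2 hetero atoms), on an aromatic carbon. The cyclopropyl-bearing group leaves, and a group with a five-membered non-aromatic ring with 1 hetero atom and 1 defined stereocentre enters.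

Within the data shown here, only one measured step bears on this, and only loosely: a number 11.3 percentage points lower from compound 1 to compound 2 (beyond the scatter), with (pyridin-2-yl)methyl in place of cyclopropyl on an amine nitrogen in a ring. That step also removes the cyclopropyl, but it puts in a different group, and no measurement tests the new ring directly. The data give no direction for this change, so no shift beyond the scatter is expected in this assay. The expected step is a number 1.5 percentage points lower from compound 1 to compound 3 (within the scatter) as an estimate from this thin evidence. In this assay compound 3 is expected at 14% with an estimated range of 4% to 32% for this measurement.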

Compound 3, percent of the compound remaining: 52.2%
Compound 3: the middle estimate sits 38.2 percentage points below what was measured, outside the stated range (above it).
By their numbers in this assay, from the lowest: compound 2; then compound 1; then compound 3.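

In this assay, this position on an aromatic carbon, ortho to a fused ring, responds strongly to how the same atoms are joined: a number 36.7 percentage points higher from compound 1 to compound 3 (beyond the scatter). The step replaces the 4-cyclopropylpiperazin-1-yl group with a group that has a five-membered non-aromatic ring and one defined stereocentre, while the counts of heavy atoms, hydrogen-bond donors and hydrogen-bond acceptors stay the same. The earlier step at this group ran only downward, a number 11.3 percentage points lower from compound 1 to compound 2 (beyond the scatter), whereas this one shows that a change here can also raise the number, though nothing at hand accounts for the rise.

The compounds shown leave open whether the higher number depends on the five-membered ring itself or on its defined stereocentre, a question that the mirror-image stereocentre would address. They also leave open whether a small open-chain group such as methyl or isopropyl, in place of cyclopropyl, would move the number in the same direction as compound 3 or in that of compound 2.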